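The compounds below may be only part of what the source reports. "The series", "measured", "known", "first", "only" and "open" are said of these compounds alone.

Measured so far:
compound 1 `CC(C)(C)NCc1cc(Cl)cc(Nc2nc3ccccc3n2Cc2ccc(C(F)(F)F)cc2)c1O`: 36300 nM
compound 2 `CCN(CC)Cc1cccc(Nc2nc3ccccc3n2Cc2ccc(C#N)cc2)c1O`: > 50000 nM

In an ADME assay on CHO cells (Cricetulus griseus) for inhibition, read by MTT assay (a higher number here means a weaker inhibitor, a lower number a stronger inhibitor), compound 1 gives 36300 nM. For compound 2 the read-out is only a limit of the assay, > 50000 nM, sitting at the limit of > 50000 nM in this assay, at which 1 of the 2 values shown sits. Compound 3 `CCN(CC)Cc1cccc(Nc2nc3ccccc3[nH]2)c1O` is not yet measured; it differs from compound 2 by hydrogen in place of 4-cyanobenzyl on an aromatic nitrogen. With compound 2 already at the limit, any further step in this assay cannot be resolved against the scatter, and the expected step that the limit leaves unreadable from compound 2 to compound 3 runs toward weaker inhibition, if anywhere. Compound 3 is expected at 80000 nM, in the range 30000 nM to 300000 nM, most likely reported again as a limit.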

Compound 3, half-maximal inhibitory concentration: > 50000 nM
Compound 3 was reported as a limit (the forecaster's own chance of this, stated with the estimate: 85%); the middle value is on the limit's open side.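

In this assay no step can be read between compound 2 and compound 3, as both are reported as limits: the limit of > 50000 nM in this assay, at which 2 of the 3 values shown sit.

The compounds shown leave open whether hydrogen in place of 4-cyanobenzyl on an aromatic nitrogen changes inhibition at all.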